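Replacing a branched ether chain by a straight butyl

The source may hold more compounds than are shown below. What is called first, only, known or untested is meant among the compounds shown, and "the series" means these compounds.

Two measured compounds share one core, an aminoquinoline bearing an ether side chain. Compound 1 `CC(COC(C)(C)C)Oc1cccc2ccc(N)nc12` gives 306 nM in an assay on cells with melanin-concentrating hormone receptor 1 (Homo sapiens) as the target, read by radioligand binding; a higher number here means a weaker inhibitor, a lower number a stronger inhibitor. Going by the values given here, compound 2 `CC(C)C(C)Oc1cccc2ccc(N)nc12` gives 199 nM in this assay, and the only comparison available to it, compound 1, lies within the usual scatter (a 1.5-fold lower number from compound 1 to compound 2 (0.19 log units; within the scatter)). Compound 3 `CCCCOc1cccc2ccc(N)nc12` has not yet been measured. It differs from compound 2 as follows: butyl in place of 1,2-dimethylpropyl on an oxygen on an aromatic ring. Among the compounds with values here, the single measured step, from a (tert-butoxy)methyl to an isopropyl, kept the number within scatter, so the shortening and straightening of this chain in compound 3 has no direct precedent, yet the shared core appears to carry most of the binding across both measured compounds. Compound 3 is therefore expected to land near its neighbours, with a step of about a 1.5-fold higher number from compound 2 to compound 3 (0.18 log units; within the scatter), and its estimate is 300 nM with a range from 100 nM to 900 nM in this assay.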

Compound 3, half-maximal inhibitory concentration: 789 nM
The estimate for compound 3 lay 2.6-fold (0.42 log units) below the measured number; the measured number falls inside the stated range.
By their numbers in this assay, from the lowest: compounds 2 and 1 (each within the scatter of the next); then compound 3.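

In this assay, going by these compounds alone, putting butyl in place of 1,2-dimethylpropyl on the oxygen gives a 4.0-fold higher number from compound 2 to compound 3 (0.60 log units; beyond the scatter), the first change in this short series that lies beyond the scatter. The earlier step, a 1.5-fold lower number from compound 1 to compound 2 (0.19 log units; within the scatter), stayed within the scatter, whereas this result shows that the number does respond to what sits on this oxygen, so the shared core does not fix it alone. No supporting measurement is available to explain this difference.

The compounds shown cannot separate the loss of the branch from the change in chain size, since the two change together in this single step. From the compounds shown here alone, it also remains open how a longer chain such as hexyl, a ring such as cyclohexyl or an amine at the end of the chain would read in this assay.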